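Notes on the ethyl-to-isopropyl step in this series

A few compounds are considered here, and "the series" means these few. Any claim that something is new, unique, unknown or untested is made for them only; others in the source may bear on it.

compound 1, `COCc1ncc2cnnc(SC)n12`: > 48000 nM
compound 2, `C=CCn1ncc2c(C)nc(CC)n2c1=O`: > 48000 nM

Compound 1 (`COCc1ncc2cnnc(SC)n12`) and compound 2 (`C=CCn1ncc2c(C)nc(CC)n2c1=O`) have both been run in a functional assay for inhibition, with Homo sapiens as the target; on this read-out lower numbers stand for stronger inhibition and higher numbers for weaker inhibition. In this assay compound 1 gives > 48000 nM, which is a limit of the assay and not a number. In this assay compound 2 gives > 48000 nM, again a limit and not a number. Compound 2 thus stands at the limit of > 48000 nM in this assay, at which 2 of the 2 values shown sit, and the numbers do not separate it from compound 1. Among the measured compounds shown here, no step between measured compounds is available, as compound 1 and compound 2 differ in more than one place; their two limits are all that can be said of the pair.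

Compound 3 (`C=CCn1ncc2c(C)nc(C(C)C)n2c1=O`) has not yet been measured in this assay. It carries methyl in place of hydrogen on a saturated chain carbon bound to an aromatic carbon and a saturated chain carbon; in words, methyl in place of hydrogen on a saturated chain carbon bound to an aromatic carbon and a saturated chain carbon, so that ethyl becomes isopropyl. With only limits behind it, no step beyond the usual scatter is expected in either direction in this assay, and the most likely outcome is that compound 3 also returns a limit. Compound 3 is estimated at 60000 nM, with a range of 20000 nM to 200000 nM. The step expected is a step that the limit leaves unreadable from compound 2 to compound 3.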

Compound 3, half-maximal inhibitory concentration: > 48000 nM
Compound 3 was reported as a limit (the forecaster's own chance of this, stated with the estimate: 85%); the middle value does not contradict the limit.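

No step can be read from compound 2 to compound 3 in this assay, so the change from ethyl to isopropyl shows no readable effect, and the series stands as follows: the limit of > 48000 nM in this assay, at which 3 of the 3 values shown sit.

The compounds shown leave open how strongly compound 1, compound 2 or compound 3 inhibits, and whether ethyl and isopropyl differ at all.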